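Adding Bromine to the Fluorophenyl Arm

This account rests on a few compounds, and the source may have more. Where it says the series, first, only, none or still open, it means among the compounds named here.

For the measured compounds named here, compound 2 `C=CCn1c(=O)/c(=C\c2ccccc2F)[nH]c(=O)/c1=C\c1ccccc1OC` gives 18500 nM in a functional assay on HL-60 cells (Homo sapiens) for cytotoxicity, read by CCK-8 assay, with a stated time of 72 h (on this read-out higher numbers stand for weaker inhibition and lower numbers for stronger inhibition), the highest of the three numbers so far. Compound 3 `COc1ccccc1/C=c1/[nH]c(=O)/c(=C\c2ccccc2OC)n(C)c1=O` gives 16200 nM, which lies within the scatter of compound 2. Going by the values given here, compound 1 `C=CCn1c(=O)/c(=C\c2cccc(F)c2)[nH]c(=O)/c1=C\c1ccccc1OC` gives 8890 nM, and the only single-point step among the measured compounds is a 2.1-fold higher number from compound 1 to compound 2 (0.32 log units; beyond the scatter). Compound 4 `C=CCn1c(=O)/c(=C\c2cc(Br)ccc2F)[nH]c(=O)/c1=C\c1ccccc1OC` differs from compound 2 by bromo in place of hydrogen on an aromatic carbon. Among the compounds with values here, no measured step adds a bromo, so the one step known, moving a fluoro between two positions, bears only loosely and was itself modest. On that footing compound 4 is expected to show a 1.2-fold lower number from compound 2 to compound 4 (0.09 log units; within the scatter), a step not beyond the scatter in either direction. The estimate for compound 4 is therefore 15000 nM, with a range from 5000 nM to 45000 nM.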

Compound 4, half-maximal inhibitory concentration: 17400 nM
For compound 4 the middle estimate is 1.2-fold (0.06 log units) below the measured one, and the stated range covers the measured number.
By their numbers in this assay, from the lowest: compounds 1, 3, 4 and 2 (each within the scatter of the next, the first and the last beyond it).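

In this assay, bromo on the aromatic carbon para to a fluoro group gives a 1.1-fold lower number from compound 2 to compound 4 (0.03 log units; within the scatter), so this position takes the added bromine atom with no change beyond the scatter. Beside the 3-fluorophenyl arm, the 5-bromo-2-fluorophenyl arm shows a 2.0-fold higher number from compound 1 to compound 4 (0.29 log units; within the scatter), which also stays within the scatter. Nothing at hand accounts for these results. As far as these compounds go, whether an amine or a carboxylic acid on that carbon would leave the number as little moved remains open. So does whether bromo would behave alike on the 3-fluorophenyl arm of compound 1.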